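Cytotoxicity of two aminothiazole ethers and a third analogue

This account rests on a few compounds, and the source may have more. Where it says the series, first, only, none or still open, it means among the compounds named here.

Compounds measured so far:
compound 1 `Clc1ccc(C(Oc2ccc3cc(Br)ccc3c2)c2cnc(NCC3CCCCC3)s2)cc1`, in an ADME assay on HepG2 2.2.15 cells (Homo sapiens) for cytotoxicity (on this read-out lower numbers stand for higher toxicity in this test and higher numbers for lower toxicity in this test), compound 1 gives "not toxic" (no number reported).
compound 2 `O=C(Nc1ncc(C(Oc2ccc3cc(Br)ccc3c2)c2ccc(Cl)cc2)s1)c1ccc(F)cc1Br`, in this assay compound 2 gives > 50000 nM.

The two compounds share a core that carries a bromonaphthyl ether and a chlorophenyl group; they differ in the group attached to the ring nitrogen. Compound 2 does not have a single number in this assay: its result is a limit of the test, as noted in the limit of > 50000 nM in this assay, at which 1 of the 2 values shown sits. Compound 1 also has no number, only the remark that it shows no toxicity.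

Compound 3 `Cc1noc(C)c1C(=O)Nc1ncc(C(Oc2ccc3cc(Br)ccc3c2)c2ccc(Cl)cc2)s1` keeps the whole core of compound 2 and changes only the acyl group on the amide nitrogen: 3,5-dimethyl-1,2-oxazol-4-yl in place of 2-bromo-4-fluorophenyl on a carbonyl carbon. Within the data shown here, no measured pair in this set differs in one place, so the size of such a step is not known from the data. Since compound 2 sits at the limit and compound 1 is called not toxic, the step from compound 2 to compound 3 is expected to be a step that the limit leaves unreadable from compound 2 to compound 3, that is, nothing beyond the scatter. Compound 3 is therefore expected to give about 60000 nM, within a range from 25000 nM to 150000 nM, and most likely again only a limit.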

Compound 3, half-maximal cytotoxic concentration: "not toxic" (no number reported)
Compound 3: no number reported, so the estimate cannot be set against anything.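

Among these compounds, compound 3, like compound 1, carries only the remark "not toxic" in this assay, and no step from compound 2 to compound 3 can be read. Compound 2 gives > 50000 nM, which is a limit of the test and not a number. On these data alone, what stays open is at what concentration, if any, these compounds harm the cells, and whether the change of acyl group shifts it.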